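The compounds below may be only part of what the source reports. "The series", "measured", "known", "first", "only" and "open" are said of these compounds alone.

Three related compounds have numbers in an ADME assay on microsomes from liver (Rattus norvegicus) for metabolic stability, read by LC-MS, using NADPH, with a stated time of 10 min, tested at 0.1 uM (on this read-out higher numbers stand for fast clearance and lower numbers for slow clearance), so far. Compound 1 `CC1SC(c2cccc(C(=O)NCCCCc3ccccc3)c2)N(c2ccc(C3CC3)cc2)C1=O` gives 3130 mL.min-1.g-1 and compound 2 `COc1ccc(F)cc1N1C(=O)CSC1c1cccc(C(=O)NCCCCc2ccccc2)c1` gives 2300 mL.min-1.g-1 while compound 3 `O=C(NCCCCc1ccccc1)c1cccc(C2SCC(=O)N2c2cccc(-c3c[nH]nn3)c2)c1` stands lowest at 742 mL.min-1.g-1 on this scale. Compound 4 `C#Cc1cccc(N2C(=O)CSC2c2cccc(C(=O)NCCCCc3ccccc3)c2)c1` differs from compound 3 in one group, with ethynyl in place of 1H-1,2,3-triazol-4-yl on an aromatic carbon. Among the measured compounds shown here, the only measured step that bears on this brings the triazole in, and a 3.1-fold lower number from compound 2 to compound 3 (0.49 log units; beyond the scatter) is modest yet beyond the scatter. Taking the triazole away may reverse that, so a rise of similar size is expected, with a 3.2-fold higher number from compound 3 to compound 4 (0.51 log units; beyond the scatter) as the estimate in this assay for this change. Compound 4 is estimated at 2400 mL.min-1.g-1 within a range from 1100 mL.min-1.g-1 to 4800 mL.min-1.g-1 for this measurement.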

Compound 4, intrinsic clearance in microsomes: 1820 mL.min-1.g-1
Compound 4: middle estimate off by 1.3-fold (0.12 log units), on the high side; low and high end bracket the measured number.
By their numbers in this assay, from the lowest: compound 3; then compounds 4, 2 and 1 (each within the scatter of the next).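

In this assay, putting ethynyl in place of the 1H-1,2,3-triazol-4-yl on the same aromatic carbon gives a 2.5-fold higher number from compound 3 to compound 4 (0.39 log units; beyond the scatter), so this single swap shows that the lower clearance reading goes with the triazole, not simply with any group at this place. The aryl groups of the other pair cannot be told apart, with a 1.3-fold lower number from compound 2 to compound 4 (0.10 log units; within the scatter). Nothing measured here explains the triazole's link to the lower number. On these data alone, whether a nitrile, an amine or a carboxylic acid at this place would match the triazole remains open.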